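Methoxy addition in a chalcone and dihydrochalcone series

The source may hold more compounds than are shown below. What is called first, only, known or untested is meant among the compounds shown, and "the series" means these compounds.

Measured compounds:
compound 1 `COc1ccc(CCC(=O)c2cccc(O)c2)cc1`: 86.3%
compound 2 `COc1ccc(/C=C/C(=O)c2ccc(OC)c(OC)c2)cc1`: 73.9%
compound 3 `COc1ccc(CCC(=O)c2cccc(O)c2)c(OC)c1`: 74.8%

In an ADME assay on RAW264.7 cells (Mus musculus) for cytotoxicity, read by MTT assay, with a stated time of 24 h, tested at 10 ug/mL (on this read-out lower numbers stand for a stronger effect and higher numbers for a weaker effect at the one concentration tested), compound 1 gives 86.3%, compound 3 gives 74.8% and compound 2 gives 73.9%. The difference between the core of compound 1 and the core of compound 2 is not broken down here. Compound 3 arises from compound 1 by methoxy in place of hydrogen on an aromatic carbon, a change that gave a number 11.5 percentage points lower from compound 1 to compound 3 (beyond the scatter). Compound 4 `COc1ccc(/C=C/C(=O)c2ccc(OC)c(OC)c2)cc1OC`, not yet measured, arises from compound 2 by methoxy in place of hydrogen on an aromatic carbon. This is the same kind of change, though the surroundings differ: in compound 3 the new group sits ortho to a large group and meta to a methoxy group, in compound 4 ortho to a methoxy group and meta to a large group. For compound 4 a step of a number 8.9 percentage points lower from compound 2 to compound 4 (within the scatter) is expected in this assay, resting on the step of a number 11.5 percentage points lower from compound 1 to compound 3 (beyond the scatter) seen with the earlier change. Compound 4 is estimated at 65%, between 52% and 78%.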

Compound 4, a percentage reported as activity, at one concentration (the size of the read-out at that concentration, not a potency): 60.4%
Compound 4: the middle estimate sits 4.6 percentage points above what was measured; the range from low to high includes it.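

In this assay the methoxy addition gives a number 13.5 percentage points lower from compound 2 to compound 4 (beyond the scatter), and the step carries over from one core to the other at about the same size: the same change on two cores in this assay, a number 11.5 percentage points lower (beyond the scatter) from compound 1 to compound 3 and a number 13.5 percentage points lower (beyond the scatter) from compound 2 to compound 4, 2 percentage points apart, within the scatter of two such steps

The two steps therefore fit a single shift for this change across the two cores shown. Two pairs, each with different surroundings for the new group, do not show why the number falls or how the change behaves on any other core.

Still open, as far as these compounds go, is whether an amine, a carboxylic acid or a longer chain such as ethoxy in place of the methoxy group would shift the number in the same way. Also open, from the compounds shown here alone, is whether the step holds at other places on the aromatic ring.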